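A few compounds are considered here, and "the series" means these few. Any claim that something is new, unique, unknown or untested is made for them only; others in the source may bear on it.

Compound 1 `CC1=NN(C(=O)CCl)C(c2cc(Br)ccc2O)C1`: 8890 nM
Compound 2 `CC1=NN(C(=O)CN2CCC(Cl)CC2)C(c2ccccc2O)C1`: 34800 nM
Compound 3 `Cc1ccc(C(=O)N2N=C(c3cc4ccccc4oc3=O)CC2c2ccccc2)cc1`: 13200 nM

All three were tested in a functional assay on PC-3 cells (Homo sapiens) for cytotoxicity, read by MTT assay, with a stated time of 48 h; a lower number here means a stronger inhibitor, a higher number a weaker inhibitor. Compound 3 gives 13200 nM, the second highest of the three numbers. Compound 1, at 8890 nM, sits within the scatter of it, whereas compound 2, at 34800 nM, lies beyond the scatter on the weaker side.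

Compound 4 `CN1CCN(CC(=O)N2N=C(c3cc4ccccc4oc3=O)CC2c2ccccc2)CC1` is not yet measured. It differs from compound 3 by (4-methylpiperazin-1-yl)methyl in place of 4-methylphenyl on a carbonyl carbon. Among the compounds with values here, no measured pair shows a change of this kind, so there is nothing to lean on. The step from compound 3 to compound 4 is expected to be a 1.1-fold higher number from compound 3 to compound 4 (0.06 log units; within the scatter), nothing beyond the scatter. Compound 4 is therefore estimated at 15000 nM, within 5000 nM to 45000 nM.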

Compound 4, half-maximal inhibitory concentration: 25800 nM
Compound 4: middle estimate off by 1.7-fold (0.24 log units), on the low side; the measured number falls inside the stated range.
By their numbers in this assay, from the lowest: compounds 1, 3, 4 and 2 (each within the scatter of the next, the first and the last beyond it).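

In this assay, (4-methylpiperazin-1-yl)methyl in place of 4-methylphenyl on a carbonyl carbon gives a 2.0-fold higher number from compound 3 to compound 4 (0.29 log units; within the scatter). At this position, then, a non-aromatic ring with two nitrogens stands in for a carbon-only aromatic ring with no change beyond the scatter. Nothing available explains this result.

This single step cannot show whether the same holds on other cores. Nor does it show how a morpholine, a carboxylic acid or a longer chain would read at this position.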